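The source may hold more compounds than are shown below. What is called first, only, known or untested is meant among the compounds shown, and "the series" means these compounds.

The measured compounds, all read in an assay on membranes from CHO cells for displacement of a labelled ligand from adenosine receptor A1 (Homo sapiens), read by scintillation counting, with a stated time of 60 min, tested at 1 uM; on this read-out lower numbers stand for less inhibition and higher numbers for more inhibition at the one concentration tested (going by the name of the read-out):
- compound 1 `CC1=C(C(=O)NC(C)C)C(c2ccoc2)NC(=O)N1` gives 1%
- compound 2 `CC1=C(C(=O)NC(C)C)C(c2ccsc2)NC(=O)N1` gives 8%
- compound 3 `CC1=C(c2ncc(C)o2)C(c2ccsc2)NC(=O)N1` gives 34%

Compound 2 stands second highest of the three: compound 1 lies within the scatter of it (a number 7 percentage points higher from compound 1 to compound 2 (within the scatter)), while compound 3 lies beyond it (a number 26 percentage points higher from compound 2 to compound 3 (beyond the scatter)).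

Compound 4 `CC1=C(C(=O)OC2CCCC2)C(c2ccsc2)NC(=O)N1` has not been measured. It differs from compound 2 by cyclopentyloxy in place of isopropylamino on a carbonyl carbon. Of the measured steps, only the change at this same carbon bears on it: the step of a number 26 percentage points higher from compound 2 to compound 3 (beyond the scatter) was modest and upward, but it brought in an aromatic ring, whereas compound 4 brings in cyclopentyloxy, so the analogy is loose. A small upward step is therefore expected in this assay, a number 10 percentage points higher from compound 2 to compound 4 (within the scatter). Compound 4 is estimated at 18%, with a range from 0% to 45%.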

Compound 4, a percentage reported as inhibition, at one concentration (the size of the read-out at that concentration, not a potency): 5%
Beside the measured number, compound 4's estimate is 13 percentage points above it, within the range that was stated.
By their numbers in this assay, from the lowest: compounds 1, 4 and 2 (each within the scatter of the next); then compound 3.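

In this assay, cyclopentyloxy in place of isopropylamino on the carbonyl carbon gives a number 3 percentage points lower from compound 2 to compound 4 (within the scatter), so this carbon accepts a five-membered non-aromatic ring and the removal of the hydrogen-bond donor of isopropylamino without a change beyond the scatter. Going by these compounds alone, the only step beyond the scatter at this place remains the replacement of the whole isopropylcarbamoyl group by 5-methyl-1,3-oxazol-2-yl, a number 26 percentage points higher from compound 2 to compound 3 (beyond the scatter). No measured evidence bears on this result.

Still open, on these data alone, is how a carboxylic acid, a methyl ester or a longer alkyl chain would read on this carbonyl carbon. Also open, as far as these compounds go, is whether cyclopentyloxy would read the same with furan-3-yl on the saturated ring carbon.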